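Benzyl in place of 1-(ethoxycarbonyl)ethyl: working notes

The source may hold more compounds than are shown below. What is called first, only, known or untested is meant among the compounds shown, and "the series" means these compounds.

Measured in a functional assay on MDA-MB-231 cells (Homo sapiens) for inhibition, read by sulforhodamine B assay, with a stated time of 48 h; on this read-out higher numbers stand for weaker inhibition and lower numbers for stronger inhibition:
- compound 1 `COc1ccc(C(O)(Cc2ccc(C)cc2)c2cccc3ccccc23)c(OC)c1OC`: > 20000 nM
- compound 2 `CCOC(=O)C(C)C(O)(c1ccc(OC)c(OC)c1OC)c1cccc2ccccc12`: > 20000 nM

Compound 2 stands at > 20000 nM, which is a limit and not a number. Going by the values given here, the series so far offers only (the limit of > 20000 nM in this assay, at which 2 of the 2 values shown sit). Next is compound 3 `COc1ccc(C(O)(Cc2ccccc2)c2cccc3ccccc23)c(OC)c1OC`, with this change: benzyl in place of 1-(ethoxycarbonyl)ethyl on a saturated chain carbon bound to two aromatic carbons and an oxygen on a saturated carbon. Among the compounds with values here, the one measured step bearing on it is a step that the two limits leave unreadable from compound 1 to compound 2, so no size can be taken from it. In this assay no readable step in either direction is therefore expected. The expected step is a step that the limit leaves unreadable from compound 2 to compound 3. For compound 3 the estimated value is 25000 nM, with an expected range of 8000 nM to 60000 nM.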

Compound 3, half-maximal inhibitory concentration: 4780 nM
Compound 3: the middle estimate sits 5.2-fold (0.72 log units) above what was measured, and the stated range ends above it.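

In this assay, going by these compounds alone, benzyl on this saturated chain carbon gives the first readable value, with an at least 4.1-fold lower number from compound 2 to compound 3 (0.62 log units; beyond the scatter). The methyl on the aromatic carbon also matters, with an at least 4.1-fold lower number from compound 1 to compound 3 (0.62 log units; beyond the scatter). Both steps are minimum sizes, as the other two values are limits: the limit of > 20000 nM in this assay, at which 2 of the 3 values shown sit.

Still open, as far as these compounds go, is whether the aromatic ring of benzyl is what is needed at this position, or whether a longer chain such as 2-phenylethyl, or an amine on that chain, would serve as well. From the compounds shown here alone, the effect of a methoxy or chloro group on the benzyl ring also remains open.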